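Swapping Hydroxymethyl for 2-Carboxyethenyl, Starting From an Assay Limit

The compounds below may be only part of what the source reports. "The series", "measured", "known", "first", "only" and "open" are said of these compounds alone.

Compound 2 `CC(C)(C)[Si](C)(C)O[C@@H]1CCCO[C@@H]1CO` was tested in a functional assay on SW1573 cells (Homo sapiens) for antiproliferative activity, read by sulforhodamine B assay, with a stated time of 48 h; a higher number here means a weaker inhibitor of growth, a lower number a stronger inhibitor of growth. There compound 2 gives > 100000 nM, which is a limit of the assay and not a number. Compound 1 `CC(C)(C)[Si](C)(C)OC[C@H]1OCCC[C@H]1O[Si](C)(C)C(C)(C)C` gives > 100000 nM, also a limit. Compound 3 `COC(=O)/C=C/[C@H]1OCCC[C@H]1O` gives > 100000 nM, again a limit. The whole set stands at the limit of > 100000 nM in this assay, at which 3 of the 3 values shown sit, so compound 2 has no number to start from.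

Within the data shown here, the one measured step is a step that the two limits leave unreadable from compound 1 to compound 2, and it offers no size to carry forward. Compound 4 `CC(C)(C)[Si](C)(C)O[C@@H]1CCCO[C@@H]1/C=C/C(=O)O` differs from compound 2 by 2-carboxyethenyl in place of hydroxymethyl on a saturated ring carbon. Among the measured compounds shown here, no measured step touches this change. With no growth inhibition yet measured as a number in this assay, no clear step and no direction can be expected, and another limit would be the likeliest report. The expected outcome is an at least 1.1-fold lower number from compound 2 to compound 4 (0.04 log units; that floor lies within the scatter). For compound 4 the estimated value is 90000 nM, with an expected range from 30000 nM to 100000 nM.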

Compound 4, concentration for 50% growth inhibition: > 100000 nM
Compound 4 was reported as a limit; the forecaster's own chance of this, stated with the estimate: 75%; at least 1.1-fold (0.04 log units) between middle value and limit.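

In this assay compound 4 gives > 100000 nM as a limit of the assay and not a number. Among these compounds, no step from compound 2 to compound 4 can be read. The compounds shown leave open what change to the shared core, if any, would give a measurable growth inhibition: the limit of > 100000 nM in this assay, at which 4 of the 4 values shown sit.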